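A few compounds are considered here, and "the series" means these few. Any claim that something is new, unique, unknown or untested is made for them only; others in the source may bear on it.

In an in vitro ADME assay on microsomes from liver (Homo sapiens) for metabolic stability (on this read-out lower numbers stand for slow clearance and higher numbers for fast clearance), compound 1 (`O=C(O)c1ccc(NC(=O)[C@H](CC2CCCC2)n2cnc(C(F)(F)F)c2)nc1`) gives < 8 mL/min/kg as its reading, which is a limit of the assay and not a number. Compound 2 (`O=C(Nc1ccc(S(=O)(=O)O)cn1)[C@H](CC1CCCC1)n1cnc(C(F)(F)F)c1`) gives < 8 mL/min/kg as its reading, again only a limit. Compound 1 therefore stands at the low end of what has been measured (the limit of < 8 mL/min/kg in this assay, at which 2 of the 3 values shown sit). Compound 3 (`O=C(Nc1ccc(-c2nnn[nH]2)cn1)[C@H](CC1CCCC1)n1cnc(C(F)(F)F)c1`) gives 160 mL/min/kg as a true number. Putting sulfo in place of carboxy leaves a step that cannot be sized (a step that the two limits leave unreadable from compound 1 to compound 2). Putting 1H-tetrazol-5-yl in place of carboxy gives the large step (an at least 20-fold higher number from compound 1 to compound 3 (1.30 log units; beyond the scatter)), and compound 4 keeps the carboxy group that this step removes. Compound 4 (`O=C(O)c1cnc(NC(=O)[C@H](CC2CCCC2)n2cnc(C(F)(F)F)c2)cn1`) differs from compound 1 only in the ring that carries the carboxy group (5-carboxypyrazin-2-yl in place of 5-carboxypyridin-2-yl on an amide-type nitrogen). For the measured compounds named here, no measured step changes that ring, so no change beyond the scatter is expected in this assay in either direction. The estimated step is a step that the limit leaves unreadable from compound 1 to compound 4 and is expected to stay small. For compound 4 the estimate is 7 mL/min/kg with an expected range of 3 mL/min/kg to 16 mL/min/kg and a good chance that it is expected to come out as only a limit.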

Compound 4, clearance: < 8 mL/min/kg
Compound 4: no number, only a limit; the forecaster's own chance of this, stated with the estimate: 65%; the middle value lies beyond the limit too.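

Compound 4 comes out only as a limit in this assay, as compound 1 does, so no step between the two can be read; both sit at the same end of the scale: the limit of < 8 mL/min/kg in this assay, at which 3 of the 4 values shown sit.

On these data alone, whether 5-carboxypyrazin-2-yl in place of 5-carboxypyridin-2-yl changes clearance at all stays open.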